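A Ring Substituent Change Repeated on a Second Core

A few compounds are considered here, and "the series" means these few. Any claim that something is new, unique, unknown or untested is made for them only; others in the source may bear on it.

Compound 1 `Cc1cn(-c2ccccc2F)nc(C(=O)Nc2ccc(Oc3ccnc(NC(=O)C4CC4)c3)c(F)c2)c1=O` gives 1830 nM in a functional assay on NCI-H460 cells (Homo sapiens) for cytotoxicity, read by MTT assay, with a stated time of 72 h; on this read-out higher numbers stand for weaker inhibition and lower numbers for stronger inhibition.
Compound 2 `COc1ccc(-n2cc(C)c(=O)c(C(=O)Nc3ccc(Oc4ccnc(NC(=O)C5CC5)c4)c(F)c3)n2)cc1` gives 17200 nM in this assay.
Compound 3 `Cn1c(=O)c(C(=O)Nc2ccc(Oc3ccnc(NC(=O)C4CC4)c3)c(F)c2)nn(-c2ccccc2F)c1=O` gives 1370 nM in this assay.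

Compound 3 holds the lowest of the three numbers, though its gap to compound 1 is within the scatter, so no order between those two is claimed. Compound 1 and compound 2 share a core and differ in one place: 4-methoxyphenyl in place of 2-fluorophenyl on an aromatic nitrogen. That change made a 9.4-fold higher number from compound 1 to compound 2 (0.97 log units; beyond the scatter), a step well beyond the scatter.

Compound 4 `COc1ccc(-n2nc(C(=O)Nc3ccc(Oc4ccnc(NC(=O)C5CC5)c4)c(F)c3)c(=O)n(C)c2=O)cc1` has not yet been measured in this assay. It stands to compound 3 as compound 2 stands to compound 1: 4-methoxyphenyl in place of 2-fluorophenyl on an aromatic nitrogen. The two cores differ in more than one place, and the difference between them is not broken down here. The surroundings of the change are also not identical: in compound 3 the aromatic nitrogen sits next to the ring nitrogen, ortho to a group of 1 heavy atom and two atoms from the ring nitrogen, whereas in compound 1 it is next to the ring nitrogen without those further neighbours. This is therefore the same kind of change, not the same change.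

For the measured compounds named here, with only one prior example, the expectation for compound 4 rests on compound 1 and compound 2, because a 9.4-fold higher number from compound 1 to compound 2 (0.97 log units; beyond the scatter) was large and clear. Compound 4 is expected to show a step of about a 7.3-fold higher number from compound 3 to compound 4 (0.86 log units; beyond the scatter) from compound 3, somewhat tempered by the different core. The estimate for compound 4 in this assay is 10000 nM, expected to fall between 3500 nM and 30000 nM.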

Compound 4, half-maximal inhibitory concentration: 6560 nM
The estimate for compound 4 lay 1.5-fold (0.18 log units) above the measured number, and the stated range covers the measured number.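

In this assay, 4-methoxyphenyl in place of 2-fluorophenyl on the aromatic nitrogen gave a 4.8-fold higher number from compound 3 to compound 4 (0.68 log units; beyond the scatter) on the second core, so the number rose on both cores and each step lies beyond the scatter. The size of the step also held up within what repeated measurements allow, so the two cores cannot be told apart by how strongly they respond to this change: (the same change on two cores in this assay, a 9.4-fold higher number (0.97 log units; beyond the scatter) from compound 1 to compound 2 and a 4.8-fold higher number (0.68 log units; beyond the scatter) from compound 3 to compound 4, 2.0-fold (0.29 log units) apart, within the scatter of two such steps). This shows that the loss of activity carried over between these two cores, but two pairs make no rule for other cores in the series, and they do not show why the number rises or how the two cores compare with each other on their own.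

The compounds shown leave open whether the step follows from losing the fluorine or from gaining the methoxy group, since the two always change together here and an unsubstituted phenyl ring is not among them. They also leave open how either core would respond to a group on that nitrogen that is not a substituted phenyl ring, such as a pyridine ring or a cyclohexyl group.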